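The compounds below may be only part of what the source reports. "The series", "measured", "known", "first", "only" and "open" are said of these compounds alone.

Compound 1 `N#Cc1cc(=O)[nH]c(=O)n1[C@@H]1O[C@H](CO)[C@@H](O)[C@H]1O` is tested in a functional assay on SKW3 cells (Homo sapiens) for antiproliferative activity, read by WST assay, with a stated time of 3 days; on this read-out higher numbers stand for weaker inhibition and lower numbers for stronger inhibition. In this assay compound 1 gives > 50000 nM, which is a limit of the assay and not a number. So compound 1 stands only at the limit of > 50000 nM in this assay, at which 2 of the 3 values shown sit, and nothing finer is known of it. Two measured neighbours set the frame. Compound 2 `O=c1cc(I)n([C@@H]2O[C@H](CO)[C@@H](O)[C@H]2O)c(=O)[nH]1` carries iodo in place of cyano on an aromatic carbon, and in this assay compound 2 gives 18900 nM. That yields an at least 2.6-fold lower number from compound 1 to compound 2 (0.42 log units; beyond the scatter), the one readable move in the set. Compound 3 `CNc1cc(=O)[nH]c(=O)n1[C@@H]1O[C@H](CO)[C@@H](O)[C@H]1O` carries methylamino in place of cyano on an aromatic carbon. In this assay compound 3 gives > 50000 nM, again a limit of the assay. Between those two compounds there is a step that the two limits leave unreadable from compound 1 to compound 3, while between the two substituted compounds there is an at least 2.6-fold higher number from compound 2 to compound 3 (0.42 log units; beyond the scatter). Compound 4 `O=c1cc(NO)n([C@@H]2O[C@H](CO)[C@@H](O)[C@H]2O)c(=O)[nH]1` has not yet been measured. It differs from compound 1 thus: hydroxyamino in place of cyano on an aromatic carbon. Going by the values given here, this change resembles the one to compound 3, where the value stayed at the limit, more than the one to compound 2. No step beyond the scatter is therefore expected in this assay. The expected step is a step that the limit leaves unreadable from compound 1 to compound 4. For compound 4 the value is estimated at 60000 nM, between 20000 nM and 200000 nM, with a fair chance that only a limit is reported.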

Compound 4, half-maximal inhibitory concentration: > 50000 nM
Compound 4 ended at the assay's limit (the forecaster's own chance of this, stated with the estimate: 70%); the middle value lies beyond the limit too.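

In this assay, iodo at this aromatic carbon next to the ring nitrogen now stands apart from a second nitrogen-linked group as well as from methylamino, with an at least 2.6-fold higher number from compound 2 to compound 4 (0.42 log units; beyond the scatter). Compound 4 gives > 50000 nM, which is a limit of the assay and not a number, so hydroxy in place of methyl on that nitrogen brings no readable value, and the change from cyano to hydroxyamino brings none either. The steps to compound 4 from compound 1 and from compound 3 cannot be read, and iodo remains the only group at this position shown with a number, while cyano, methylamino and hydroxyamino all share one limit: the limit of > 50000 nM in this assay, at which 3 of the 4 values shown sit.

From the compounds shown here alone, how compound 1, compound 3 and compound 4 rank among themselves stays unknown, since limits give them no order, and nothing here tells how far any of them lies from that limit. Also open, going by these compounds, is whether a smaller halogen such as bromo or chloro, or a plain amine, on the same carbon would give a number in this assay, and so whether the value of compound 2 is particular to iodo.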